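The compounds below may be only part of what the source reports. "The series", "measured", "known", "first", "only" and "open" are said of these compounds alone.

Of the compounds shown here, two of a shared core have been measured in a functional assay on ECa-109 cells for inhibition, with ECa-109 cell line (Homo sapiens) as the target, read by sulforhodamine B assay; a lower number here means a stronger inhibitor, a higher number a weaker inhibitor. Compound 1, `O=C1C(Nc2ccccc2)=CC(=O)c2c1nc1n2[C@H]2OC[C@@H](O)[C@H]2OC1`, carries a phenyl on an amine nitrogen, and in this assay compound 1 gives 3560 nM. Compound 2, `O=C1C=C(Nc2ccc(C(F)(F)F)cc2)C(=O)c2c1nc1n2[C@H]2OC[C@@H](O)[C@H]2OC1`, carries a trifluoromethyl on the ring attached to the amine nitrogen, and in this assay compound 2 gives 5500 nM. The two numbers lie within the scatter of each other, so neither compound can be called the stronger inhibitor on this evidence; compound 1 simply stands as one of two closely matched results.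

The next compound, compound 3, `O=C1C(NCc2ccccc2)=CC(=O)c2c1nc1n2[C@H]2OC[C@@H](O)[C@H]2OC1`, differs from compound 1 in one place: benzyl in place of phenyl on an amine nitrogen. Among the measured compounds shown here, no pair of measured compounds shows the effect of this change, so no measured step can guide the expectation. The two known values suggest that changes on this amine nitrogen move the number little. For compound 3 the step of a 1.3-fold higher number from compound 1 to compound 3 (0.10 log units; within the scatter) is therefore expected to stay small, without a clear direction beyond the scatter. Compound 3 is estimated at 4500 nM, with a range from 1500 nM to 15000 nM.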

Compound 3, half-maximal inhibitory concentration: > 8000 nM
Compound 3 was reported as a limit (the forecaster's own chance of this, stated with the estimate: 10%); at least 1.7-fold (0.24 log units) between middle value and limit.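

Compound 3 is reported only as a limit in this assay, > 8000 nM, and not as an exact number. The values of compound 1 and compound 2 lie within the scatter of each other, so they gave no sign that a change around this amine nitrogen could matter, but benzyl in place of phenyl now gives an at least 2.2-fold higher number from compound 1 to compound 3 (0.35 log units; beyond the scatter). This makes the anilino to benzylamino change the first one here shown to weaken inhibition beyond the scatter, although the true size of the step stays open and what is known of it rests on a single reported limit: the limit of > 8000 nM in this assay, at which 1 of the 3 values shown sits.

The compounds shown do not tell how far compound 3 really lies from compound 1, so the loss could be modest or much larger. They also leave open whether a longer chain ending in phenyl on this amine nitrogen would weaken inhibition further, and whether a trifluoromethyl on the benzyl ring or a simple methyl on the nitrogen in its place would keep the number near that of compound 1.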